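A few compounds are considered here, and "the series" means these few. Any claim that something is new, unique, unknown or untested is made for them only; others in the source may bear on it.

Going by the values given here, compound 2 `Cc1ccc(OCC(=O)N(Cc2cccs2)C2COC2)cc1` stands at the higher of the two numbers measured so far. In an assay on HEK293 cells for agonist activity at transient receptor potential cation channel subfamily M member 8 (Homo sapiens), read by fluorescence and calcium flux, with a stated time of 15 min (a lower number here means that less compound is needed, a higher number that more compound is needed for the effect), compound 2 gives 23000 nM, while compound 1 `Cc1ccc(OCC(=O)N(Cc2cccs2)CC(C)C)cc1` gives 900 nM. Among the compounds with values here, the single measured step between these two, a 26-fold higher number from compound 1 to compound 2 (1.41 log units; beyond the scatter), is large and lies beyond the scatter. Compound 3 `Cc1ccc(OCC(=O)N(Cc2cccs2)C(C)C)cc1` has not yet been measured. It differs from compound 2 in one place: isopropyl in place of oxetan-3-yl on an amide-type nitrogen. This removes the group that entered between compound 1 and compound 2 and puts in its place an isopropyl, a short chain more like the isobutyl of compound 1 than the oxetan-3-yl is. Within the data shown here, the only step that bears on this move is the one from compound 1 to compound 2, so a good part of that rise is expected to be reversed, though not necessarily all of it. Compound 3 is therefore expected to show a 9.2-fold lower number from compound 2 to compound 3 (0.96 log units; beyond the scatter) in this assay, an estimate of 2500 nM with a range from 700 nM to 9000 nM.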

Compound 3, half-maximal effective concentration: 70 nM
Compound 3: the middle estimate sits 36-fold (1.55 log units) above what was measured, outside the stated range (below it).
By their numbers in this assay, from the lowest: compound 3; then compound 1; then compound 2.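

In this assay, isopropyl does far more than win back what the oxetan-3-yl cost, with a 330-fold lower number from compound 2 to compound 3 (2.52 log units; beyond the scatter) and a number that ends up under that of compound 1. Isopropyl in place of isobutyl gives a 13-fold lower number from compound 1 to compound 3 (1.11 log units; beyond the scatter), so two open-chain groups without a ring also sit far apart, and this amide-type nitrogen proves sensitive to small changes in its group, something compound 1 and compound 2 alone could not show. Nothing measured here says why these groups differ so much.

On these data alone, it remains open whether the high number of compound 2 goes with the four-membered ring or with its oxygen, and a cyclobutyl group on the same nitrogen would separate the two. Also open, as far as these compounds go, is where an ethyl or a tert-butyl group would fall in this order.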